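A Fluorophenyl Swap on the Shared Core

A few compounds are considered here, and "the series" means these few. Any claim that something is new, unique, unknown or untested is made for them only; others in the source may bear on it.

Measured in a functional assay on A549 cells (Homo sapiens) for cytotoxicity, read by MTT assay, with a stated time of 48 h; a lower number here means a stronger inhibitor, a higher number a weaker inhibitor:
compound 1 `COc1ccc(OC)c(C2=NOC(COc3ccc(-c4nnnn4-c4cc(OC)c(OC)c(OC)c4)cc3N)C2)c1` gives 1930 nM
compound 2 `COc1ccc(C2=NOC(COc3ccc(-c4nnnn4-c4cc(OC)c(OC)c(OC)c4)cc3N)C2)cc1OC` gives 2520 nM
compound 3 `COc1ccc(C2=NOC(COc3ccc(-c4nnnn4-c4cc(OC)c(OC)c(OC)c4)cc3N)C2)cc1O` gives 2130 nM

Among these three, compound 1 stands lowest, with compound 3 nearest and compound 2 furthest, and both gaps are within the scatter. Each compound differs only in the aryl group on a carbon with a double bond to nitrogen. The change a 1.3-fold higher number from compound 1 to compound 2 (0.12 log units; within the scatter) and the change a 1.1-fold higher number from compound 1 to compound 3 (0.04 log units; within the scatter) both leave the number essentially where it was, and a 1.2-fold lower number from compound 2 to compound 3 (0.07 log units; within the scatter) is equally small. Nothing in this set shows that the aryl group at this position moves the number beyond the scatter.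

Compound 4 `COc1cc(-n2nnnc2-c2ccc(OCC3CC(c4ccccc4F)=NO3)c(N)c2)cc(OC)c1OC` is not yet measured. It differs from compound 1 by 2-fluorophenyl in place of 2,5-dimethoxyphenyl on a carbon with a double bond to nitrogen. Because a 1.3-fold higher number from compound 1 to compound 2 (0.12 log units; within the scatter) and a 1.1-fold higher number from compound 1 to compound 3 (0.04 log units; within the scatter) stayed within the scatter when the same position was varied, the same outcome is expected here, with no direction favoured. The step from compound 1 to compound 4 is therefore estimated as a 1.1-fold higher number from compound 1 to compound 4 (0.06 log units; within the scatter). In this assay compound 4 is expected to give about 2200 nM, within a range from 1000 nM to 5000 nM.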

Compound 4, half-maximal inhibitory concentration: 1490 nM
Compound 4: the middle estimate sits 1.5-fold (0.17 log units) above what was measured, and the stated range covers the measured number.
By their numbers in this assay, from the lowest: compounds 4, 1, 3 and 2 (each within the scatter of the next).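

In this assay the 2-fluorophenyl group of compound 4 stays within the scatter of all three earlier aryl groups: against 2,5-dimethoxyphenyl (a 1.3-fold lower number from compound 1 to compound 4 (0.11 log units; within the scatter)), against 3-hydroxy-4-methoxyphenyl (a 1.4-fold lower number from compound 3 to compound 4 (0.16 log units; within the scatter)) and against 3,4-dimethoxyphenyl (a 1.7-fold lower number from compound 2 to compound 4 (0.23 log units; within the scatter)). The earlier compounds shown here varied this position only among phenyl groups carrying methoxy or hydroxy groups, whereas compound 4 shows that a phenyl group with neither, bearing fluorine instead, with fewer heavy atoms and no hydrogen-bond acceptors, also leaves the number inside the scatter. No measurement here bears on why these steps are so small.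

The compounds shown all keep a substituted phenyl group at this position, which leaves open whether a pyridyl ring, a cyclohexyl group or a phenyl group carrying a carboxylic acid would move the number beyond the scatter. They also leave open what an acetamide in place of the amine on the shared core would do, since that amine is common to all four compounds.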